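The source may hold more compounds than are shown below. What is called first, only, known or untested is meant among the compounds shown, and "the series" means these compounds.

Measured in an ADME assay on MDBK cells (Bos taurus) for cytotoxicity, read by MTT assay, with a stated time of 72 h; a higher number here means that more compound is tolerated, a lower number that less compound is tolerated:
Compound 1 `Brc1ccc(NCc2cn(-c3ccccc3)nc2-c2ccccc2)cc1`: > 100000 nM, a limit.
Compound 2 `FC(F)(F)c1ccc(NCc2cn(-c3ccccc3)nc2-c2ccc(C(F)(F)F)cc2)cc1`: 26000 nM.
Compound 3 `Cc1ccc(NCc2cn(-c3ccccc3)nc2-c2ccccc2)cc1`: > 100000 nM, a limit.

Compound 3 has no number in this assay, only a limit, and it stands at the limit of > 100000 nM in this assay, at which 2 of the 3 values shown sit. Compound 4 `FC(F)(F)c1ccc(NCc2cn(-c3ccccc3)nc2-c2ccccc2)cc1` departs from compound 3 by one change, trifluoromethyl in place of methyl on an aromatic carbon, para to a large group. For the measured compounds named here, the only measured single change, a step that the two limits leave unreadable from compound 1 to compound 3, involves another pair of groups and offers no size to carry over. Going by the values given here, the sole number comes from a compound that holds trifluoromethyl like compound 4 but also a second such group: compound 2 gives 26000 nM. On that single value, a modest move towards less compound being tolerated is expected, though compound 4 may well stay at the limit. The expected change is an at least 1.6-fold lower number from compound 3 to compound 4 (0.22 log units; that floor lies within the scatter). For compound 4 the estimated value is 60000 nM, with an expected range of 25000 nM to 100000 nM.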

Compound 4, half-maximal cytotoxic concentration: 34000 nM
For compound 4 the middle estimate is 1.8-fold (0.25 log units) above the measured one; low and high end bracket the measured number.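

In this assay, for the compounds shown here, trifluoromethyl para to a large group gives the first step of readable size at this position: an at least 2.9-fold lower number from compound 3 to compound 4 (0.46 log units; beyond the scatter), and the change from bromo reads an at least 2.9-fold lower number from compound 1 to compound 4 (0.46 log units; beyond the scatter). Both steps start from compounds that carry only a limit, so their full size cannot be read: the limit of > 100000 nM in this assay, at which 2 of the 4 values shown sit. Going by these compounds alone, the second trifluoromethyl of compound 2 adds nothing that can be told apart, as a 1.3-fold higher number from compound 2 to compound 4 (0.12 log units; within the scatter) stays within the scatter, so the single group in compound 4 already accounts for the fall in tolerated compound.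

Going by these compounds, it remains open whether a nitrile or a methoxy group at this place would also lower the number or would stay at the limit. On these data alone, it also remains open what a trifluoromethyl at the second site of compound 2 would do on its own.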